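Methoxy removal on the benzyl ring of compound 2

The source may hold more compounds than are shown below. What is called first, only, known or untested is meant among the compounds shown, and "the series" means these compounds.

Measured so far in an assay on isolated protein for inhibition of G protein-coupled receptor kinase 6 (Homo sapiens), read by scintillation counting, radiometric assay and 33P incorporation, with a stated time of 80 min, in the presence of a further agent that is not named here; a lower number here means a stronger inhibitor, a higher number a weaker inhibitor:
compound 1, `CCc1cc(Nc2nc(N[C@@H](C)c3ccc(F)cc3)nc3ccccc23)n[nH]1`, 120 nM
compound 2, `CCc1cc(Nc2nc(NCc3ccc(Cl)cc3OC)nc3cccc(C)c23)n[nH]1`, 6 nM
compound 3, `CCc1cc(Nc2nc(N[C@@H](C)c3ccc(F)cc3)nc3ccc(OC)cc23)n[nH]1`, 140 nM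

Compound 2 gives the lowest number of the three in this assay, and both compound 1 and compound 3 lie well beyond the scatter above it. The difference between the core of compound 2 and the core of compound 3 is not broken down here.

Within the data shown here, the only single change measured is hydrogen in place of methoxy on an aromatic carbon, which gave a 1.2-fold lower number from compound 3 to compound 1 (0.07 log units; within the scatter). The step to compound 4, `CCc1cc(Nc2nc(NCc3ccc(Cl)cc3)nc3cccc(C)c23)n[nH]1`, is hydrogen in place of methoxy on an aromatic carbon. The two are the same kind of change, but the places are not the same: in compound 3 the methoxy sits on a ring that is part of a fused or bridged system of two rings, meta to a fused ring and para to a fused ring, whereas in compound 2 it sits on a six-membered aromatic ring of carbon only, ortho to a large group and meta to a chloro group. Whether the second place tolerates the loss as quietly as the first is not shown by any measured pair.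

Because compound 3 to compound 1 moved only a 1.2-fold lower number from compound 3 to compound 1 (0.07 log units; within the scatter), the expected step for compound 4 in this assay is a 2.5-fold higher number from compound 2 to compound 4 (0.40 log units; beyond the scatter), a modest rise allowed for the different place. Compound 4 is estimated at 15 nM, with a range from 4 nM to 60 nM.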

Compound 4, half-maximal inhibitory concentration: 27 nM
The estimate for compound 4 lay 1.8-fold (0.26 log units) below the measured number, within the range that was stated.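

In this assay, hydrogen in place of methoxy on the 4-chloro-2-methoxybenzyl group gives a 4.5-fold higher number from compound 2 to compound 4 (0.65 log units; beyond the scatter), so compound 4 keeps a measurable inhibition after the loss of the methoxy, but the step is not a quiet one. The same kind of change does not carry over as one fixed step between the two cores: the same change on two cores in this assay, a 1.2-fold lower number (0.07 log units; within the scatter) from compound 3 to compound 1 and a 4.5-fold higher number (0.65 log units; beyond the scatter) from compound 2 to compound 4, 5.3-fold (0.72 log units) apart, beyond the scatter of two such steps The two pairs differ both in the core and in the place of the methoxy, so the gap cannot be assigned to either one, and a single pair on each core gives no rule for a further core.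

The compounds shown leave open what other groups do at the place on the aromatic carbon ortho to a large group and meta to a chloro group, for example a hydroxyl, an ethoxy or a fluoro group, any of which would show whether the methoxy itself matters or whether any group there would serve. Also open, as far as these compounds go, is the same methoxy removal from a 4-chloro-2-methoxybenzyl group set on the core of compound 1, a pair that would keep the place fixed and vary only the core.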